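A few compounds are considered here, and "the series" means these few. Any claim that something is new, unique, unknown or untested is made for them only; others in the source may bear on it.

Measured in a functional assay on NCI/ADR-RES cells (Homo sapiens) for positive allosteric modulation, read by MTT assay, with a stated time of 48 h, tested at 10 uM; on this read-out lower numbers stand for stronger inhibition and higher numbers for weaker inhibition:
- compound 1 `C=C1[C@H](OC(C)=O)[C@@H](OC(C)=O)[C@@H](O)C(C)(C)/C=C/[C@H](C)[C@H](OC(=O)c2ccccc2)[C@@]2(O)C[C@@](C)(O)[C@H](OC(C)=O)[C@@H]2[C@H]1OCC(C)C`: > 100000 nM, a limit of the assay
- compound 2 `C=C1[C@H](OC(C)=O)[C@@H](OC(C)=O)[C@@H](OC(C)=O)C(C)(C)/C=C/[C@H](C)[C@H](OC(=O)c2ccccc2)[C@@]2(O)C[C@@](C)(O)[C@H](OC(C)=O)[C@@H]2[C@H]1OCC(C)C`: 13000 nM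
- compound 3 `C=C1[C@H](OC(C)=O)[C@@H](OC(C)=O)[C@@H](OC(C)=O)C(C)(C)/C=C/[C@H](C)[C@H]2O[C@]3(C)C[C@@]2(OC(=O)c2ccccc2)[C@H]([C@H]3OC(C)=O)[C@H]1OCC(C)C`: 1700 nM

Among the values that are numbers, compound 3 has the lowest at 1700 nM, and its gap to compound 2 lies beyond the scatter. The next change leads to compound 4 `C=C1[C@H](OC(C)=O)[C@@H](OC(=O)c2cccc(C)c2)[C@@H](OC(C)=O)C(C)(C)/C=C/[C@H](C)[C@H]2O[C@]3(C)C[C@@]2(OC(=O)c2ccccc2)[C@H]([C@H]3OC(C)=O)[C@H]1OCC(C)C`: 3-methylphenyl in place of methyl on a carbonyl carbon. In words, this is 3-methylphenyl in place of methyl on a carbonyl carbon, or acetyl to (3-methylphenyl)carbonyl.

Among the measured compounds shown here, no measured step exchanges one acyl group for another. The closest is an at least 7.6-fold lower number from compound 1 to compound 2 (0.88 log units; beyond the scatter), with acetyl in place of hydrogen on an oxygen on a saturated carbon. For compound 1, that size rests on (the limit of > 100000 nM in this assay, at which 1 of the 3 values shown sits). That step adds an acyl group, whereas compound 4 keeps one and only exchanges it, so a much smaller shift is expected here. The expected change is a 1.4-fold lower number from compound 3 to compound 4 (0.15 log units; within the scatter), which means no clear step beyond the scatter, with a slight lean towards lower numbers. For compound 4, the estimated value is 1200 nM, within an expected range of 300 nM to 5000 nM.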

Compound 4, half-maximal inhibitory concentration: 6570 nM
The estimate for compound 4 lay 5.5-fold (0.74 log units) below the measured number, and the stated range ends below it.
By their numbers in this assay, from the lowest: compound 3; then compounds 4 and 2 (each within the scatter of the next). At a limit, above all of these: compound 1.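

this assay now holds a first reading of one acyl group exchanged for another: acetyl to (3-methylphenyl)carbonyl gives a 3.9-fold higher number from compound 3 to compound 4 (0.59 log units; beyond the scatter). At this place, acetyl therefore reads better than the larger aromatic acyl group, although the loss is modest and compound 4 still gives a measurable number, so this single pair shows that an aromatic ring can be carried here without the activity being lost altogether. Nothing in the data shown gives a cause for this shift.

Going by these compounds, it remains open whether the shift follows the ring itself or its methyl, which unsubstituted benzoyl would separate, and whether a longer chain such as butanoyl or an acyl group carrying an amine would read closer to acetyl. Also open, on these data alone, is whether the same exchange at the other acetoxy groups of the shared core would move the number in the same direction.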